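Swapping the amide substituent on compound 2

The compounds below may be only part of what the source reports. "The series", "measured", "known", "first", "only" and "open" are said of these compounds alone.

Of the compounds shown here, two have been measured in an assay on isolated protein for inhibition of tyrosine-protein kinase ZAP-70 (Homo sapiens), read by HTRF, tested at 10 uM (a lower number here means less inhibition, a higher number more inhibition at the concentration tested (going by the name of the read-out)), so far. Compound 1 `Clc1ccc2sc(CN3CCN(c4ncnc5c4CN(Cc4ccccc4)CC5)CC3)cc2c1` gives 5%, and compound 2 `CN(CCCn1ccnc1)C(=O)[C@@H]1CCCN1c1nccc(Nc2ccccc2)n1` gives 3%. On these two numbers compound 2 stands lowest, but its nearest neighbour, compound 1, lies within the scatter of repeated measurements, so the two compounds cannot be told apart in this assay. Both show little inhibition at the concentration tested.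

Compound 3 `COC[C@@H]1CCCN1C(=O)[C@@H]1CCCN1c1nccc(Nc2ccccc2)n1` is not yet measured. It differs from compound 2 in one place: 2-(methoxymethyl)pyrrolidin-1-yl in place of (3-(1H-imidazol-1-yl)propyl)(methyl)amino on a carbonyl carbon. Among the measured compounds shown here, no pair of measured compounds shows a step in this assay, so there is nothing to say how large an effect such a change might have. Given that compound 2 shows 3%, the step of a number 1 percentage points higher from compound 2 to compound 3 (within the scatter) is expected to be small, with no direction beyond the scatter. Compound 3 is therefore estimated at 4%, within -5% to 15%.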

Compound 3, a percentage reported as inhibition, at one concentration (the size of the read-out at that concentration, not a potency): 6%
Estimate against measurement, compound 3: 2 percentage points below, within the range that was stated.
By their numbers in this assay, from the lowest: compounds 2, 1 and 3 (each within the scatter of the next).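

In this assay, putting 2-(methoxymethyl)pyrrolidin-1-yl in place of (3-(1H-imidazol-1-yl)propyl)(methyl)amino on a carbonyl carbon gives a number 3 percentage points higher from compound 2 to compound 3 (within the scatter), so the two compounds cannot be told apart. Among the compounds shown here, this is the first view of this position: two groups with different rings, one aromatic with 2 hetero atoms and one non-aromatic with 1 hetero atom and a defined stereocentre, leave the inhibition equally small at the concentration tested. Nothing measured here explains this result.

Going by these compounds, it remains open whether any group on this carbonyl carbon can lift the number beyond the scatter, for example a chain ending in a primary amine or a simple morpholine ring. With every value this low, the compounds shown also say nothing about which parts of the shared core matter.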